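The source may report more compounds than this note shows. Statements on the series, on what has been measured and on what is new or still open speak of the compounds shown alone.

Series notes, whole-animal dosing.

Three members of the series have a value in a functional assay on the whole organism with Rattus norvegicus as the target (a higher number here means that more compound is needed for the effect, a lower number that less compound is needed), so far. Compound 1 `CCC(C)(C)c1ccc2nc(N)sc2c1` is the one for which only a limit is recorded: in this assay compound 1 gives > 10 mg/kg, a limit of the assay rather than a number, the point noted as the limit of > 10 mg/kg in this assay, at which 1 of the 3 values shown sits. Compound 2 `Nc1nc2ccc(OC(F)(F)C(F)F)cc2s1` gives 8.5 mg/kg in this assay. Compound 3 `CCn1c(=N)sc2cc(OC(F)(F)F)ccc21` gives 5 mg/kg in this assay, the lowest of the two numbers, though its separation from compound 2 lies within the scatter, so no order between the two is claimed.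

Compound 4 `CCN(CC)C(=O)Cn1c(=N)sc2cc(OC(F)(F)F)ccc21` is the next member, not yet dosed. It differs from compound 3 by diethylcarbamoyl in place of methyl on a saturated chain carbon bound to an aromatic nitrogen, with no further change to the shared core or to the trifluoromethoxy group. Among the measured compounds shown here, no measured pair shows a comparable change, so nothing in the numbers so far anchors its effect. The step from compound 3 to compound 4 in this assay is expected to be a 1.4-fold higher number from compound 3 to compound 4 (0.15 log units; within the scatter), that is, at most a modest shift toward a higher dose, likely within the scatter. Compound 4 is therefore estimated at 7 mg/kg in this assay, with a range from 2.5 mg/kg to 20 mg/kg.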

Compound 4, dose for half-maximal effect: 9 mg/kg
Compound 4: the middle estimate sits 1.3-fold (0.11 log units) below what was measured; low and high end bracket the measured number.
By their numbers in this assay, from the lowest: compounds 3, 2 and 4 (each within the scatter of the next). At a limit, above all of these: compound 1.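

In this assay, among the compounds shown here, compounds 3 and 4 form the first pair that differ in one place, and the exchange of methyl for diethylcarbamoyl on a saturated chain carbon bound to an aromatic nitrogen gives a 1.8-fold higher number from compound 3 to compound 4 (0.26 log units; within the scatter). This position therefore accepts a much larger group carrying a hydrogen-bond acceptor, with no difference that can be read in whole-animal dosing. No measurement at hand bears on the size of this step.

On these data alone, whether the same holds for other groups on this chain carbon remains open, for example a primary amine, a carboxylic acid or a longer alkyl chain. Also open, as far as these compounds go, is whether the step would carry over to a core bearing something other than the trifluoromethoxy group, which stays the same in this pair.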